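The source may hold more compounds than are shown below. What is called first, only, known or untested is meant among the compounds shown, and "the series" means these compounds.

Working notes on the series in an ADME assay on HEL cells (Homo sapiens) for cytotoxicity; on this read-out higher numbers stand for lower toxicity in this test and lower numbers for higher toxicity in this test.

For the measured compounds named here, compound 1 `O=C(COc1cccc2ccccc12)N/N=C/c1ccc(O)cc1` stands second highest of the three numbers so far: in this assay compound 1 gives 60.6 ug/mL. Compound 3 `C/C(=N\NC(=O)COc1cccc2ccccc12)c1ccc(O)cc1O` sits nearest; in this assay compound 3 gives 74.8 ug/mL, and the two values lie within the scatter of each other. Compound 2 `O=C(COc1cccc2ccccc12)N/N=C/c1ccc([N+](=O)[O-])cc1` is furthest; in this assay compound 2 gives 14.2 ug/mL, and the step from compound 1 to compound 2 is a 4.3-fold lower number from compound 1 to compound 2 (0.63 log units; beyond the scatter).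

Compound 4 `O=C(COc1cccc2ccccc12)N/N=C/c1ccccc1Cl` has not yet been measured. It differs from compound 1 at one place: 2-chlorophenyl in place of 4-hydroxyphenyl on a carbon with a double bond to nitrogen. Going by the values given here, the only measured step touching the same part of the shared core is the one to compound 2, where the hydroxy was replaced and the number fell modestly by a 4.3-fold lower number from compound 1 to compound 2 (0.63 log units; beyond the scatter). Here the hydroxy group is again lost and no donor or acceptor enters, so a drop of similar or somewhat smaller size is expected rather than none.

For compound 4 the number expected in this assay is 32 ug/mL, with a range of 14 ug/mL to 75 ug/mL, which is an estimated step of a 1.9-fold lower number from compound 1 to compound 4 (0.28 log units; within the scatter) from compound 1.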

Compound 4, half-maximal cytotoxic concentration: 62.7 ug/mL
Estimate against measurement, compound 4: 2.0-fold (0.29 log units) below; the range from low to high includes it.
By their numbers in this assay, from the lowest: compound 2; then compounds 1, 4 and 3 (each within the scatter of the next).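

In this assay the change from 4-hydroxyphenyl to 2-chlorophenyl on a carbon with a double bond to nitrogen gives a 1.0-fold higher number from compound 1 to compound 4 (0.01 log units; within the scatter) and so shows that this position tolerates the loss of the hydroxy group, with its hydrogen-bond donor and acceptor, without a step beyond the scatter. The earlier step of a 4.3-fold lower number from compound 1 to compound 2 (0.63 log units; beyond the scatter) therefore cannot be read as the result of losing the hydroxy group alone, and what enters counts at this position. No measurement at hand explains why the two replacements part ways.

The 2-chlorophenyl change alters both the group and where it sits on the ring, so these two differences remain tied together. An unsubstituted phenyl, a 4-chlorophenyl or a 4-aminophenyl at this place would help to separate them.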